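Swapping the aryl group on the hydrazone: compound 3 expected

The compounds below may be only part of what the source reports. "The series", "measured", "known", "first", "only" and "open" are said of these compounds alone.

Measured compounds:
compound 1 `O=C(N/N=C/c1cccc(O)c1)c1cccnc1Nc1cccc(C(F)(F)F)c1` gives 63.8% in a functional assay on the whole organism (strain Wistar) for inhibition, with Rattus norvegicus as the target, read by paw edema, with a stated time of 1 h, at a dose of 10 mg/kg by the intraperitoneal route; a higher number here means more inhibition at the dose given (going by the name of the read-out), a lower number less inhibition
compound 2 `COc1ccc(/C=N/NC(=O)c2cccnc2Nc2cccc(C(F)(F)F)c2)c(OC)c1` gives 55.7% in this assay

Compound 2 has the lower of the two numbers in this assay, though the step of a number 8.1 percentage points lower from compound 1 to compound 2 (within the scatter) lies within the scatter, so the two compounds cannot be ranked. Compound 3 `CN(C)c1ccc(/C=N/NC(=O)c2cccnc2Nc2cccc(C(F)(F)F)c2)cc1` carries a different aryl group on the same core; the change is 4-(dimethylamino)phenyl in place of 2,4-dimethoxyphenyl on a carbon with a double bond to nitrogen. Going by the values given here, the only step that bears on this change is the earlier aryl swap, which stayed within the scatter, so no step beyond the scatter is expected in this assay. Compound 3 is therefore estimated at 58%, between 42% and 74%, an expected step of a number 2.3 percentage points higher from compound 2 to compound 3 (within the scatter).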

Compound 3, a percentage reported as inhibition, in the whole organism at one dose (the size of the read-out at that dose, not a potency): 63.5%
For compound 3 the middle estimate is 5.5 percentage points below the measured one, and the stated range covers the measured number.
By their numbers in this assay, from the lowest: compounds 2, 3 and 1 (each within the scatter of the next).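

In this assay, a third aryl group on the carbon with a double bond to nitrogen again stays within the scatter (a number 7.8 percentage points higher from compound 2 to compound 3 (within the scatter)) and matches the hydroxyl-bearing ring as well (a number 0.3 percentage points lower from compound 1 to compound 3 (within the scatter)). At this position, 4-(dimethylamino)phenyl therefore cannot be told apart from 2,4-dimethoxyphenyl or 3-hydroxyphenyl, so the three compounds cannot be ranked. Nothing available explains this result. Still open, on these data alone, is whether a non-aromatic group, such as cyclohexyl, or a ring carrying a carboxylic acid would step beyond the scatter at this position.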